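Swapping the aryl substituent on the fused core

A few compounds are considered here, and "the series" means these few. Any claim that something is new, unique, unknown or untested is made for them only; others in the source may bear on it.

For the measured compounds named here, compound 2 `CC(C)OC(=O)N1CCC(Oc2ncnc3c2CCN3c2ccc([S+]([O-])N(C)C)cc2)CC1` gives 501 nM in a functional assay on CHO-K1 cells for agonist activity at Glucose-dependent insulinotropic receptor (Homo sapiens), read by a luciferase reporter, with a stated time of 5 h (on this read-out lower numbers stand for an effect already at smaller amounts and higher numbers for an effect only at larger amounts of compound), the highest of the two numbers measured so far. Going by the values given here, compound 1 `CC(C)OC(=O)N1CCC(Oc2ncnc3c2CCN3c2ccc(C#N)cc2F)CC1`, which differs from it in one place only, gives 63.1 nM in this assay; the single measured step, a 7.9-fold higher number from compound 1 to compound 2 (0.90 log units; beyond the scatter), is all that is available for comparison. Compound 3 `CSc1ccc(N2CCc3c(OC4CCN(C(=O)OC(C)C)CC4)ncnc32)cc1F` has not yet been measured. It differs from compound 2 by a group of 9 heavy atoms (7 carbon, 1 fluorine, 1 sulfur; one six-membered aromatic ring of carbon only) in place of a group of 11 heavy atoms (8 carbon, 1 nitrogen, 1 oxygen, 1 sulfur; one six-membered aromatic ring of carbon only), on a nitrogen on an aromatic ring in a ring. The step from compound 1 to compound 2 bears on this change only loosely: compound 3 brings a fluorine back onto the ring, as in compound 1, while keeping a sulfur, as in compound 2. The expected step of a 3.9-fold lower number from compound 2 to compound 3 (0.59 log units; beyond the scatter) is a fall toward compound 1, beyond the scatter but smaller than the measured step. For compound 3 the estimated value is 130 nM, with a range from 40 nM to 400 nM.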

Compound 3, half-maximal effective concentration: 398 nM
Compound 3: the middle estimate sits 3.1-fold (0.49 log units) below what was measured; the measured number falls inside the stated range.
By their numbers in this assay, from the lowest: compound 1; then compounds 3 and 2 (each within the scatter of the next).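

In this assay, exchanging the aryl group of compound 2 for the one carrying fluorine and a sulfur-linked methyl gives a 1.3-fold lower number from compound 2 to compound 3 (0.10 log units; within the scatter), so these two quite different groups on the ring nitrogen cannot be told apart here. The other comparison gives a 6.3-fold higher number from compound 1 to compound 3 (0.80 log units; beyond the scatter), which shows that a fluorine on the ring does not by itself bring the number back to that of compound 1. Among these three compounds, compound 1, the one with the nitrile, is thus the only one that stands apart.

No measurement available explains this separation. Still open, on these data alone, is whether the nitrile alone accounts for it, and how a ring bearing a methylsulfonyl group or an amine would read in this position.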